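A cyano group in place of fluoro

The source may report more compounds than this note shows. Statements on the series, on what has been measured and on what is new or still open speak of the compounds shown alone.

In an ADME assay on microsomes from liver (Mus musculus) for pharmacokinetics (on this read-out higher numbers stand for fast clearance and lower numbers for slow clearance), compound 1 (`C[C@H](NC(=O)C1CCOCC1)c1ccc(NC(=O)[C@H]2C[C@@H]2c2cccnc2)cc1`) gives 25.1 mL.min-1.g-1 and compound 2 (`C[C@H](NC(=O)c1ccc(F)cc1)c1ccc(NC(=O)[C@H]2C[C@@H]2c2cccnc2)cc1`) gives 13.7 mL.min-1.g-1 so these two sit within the scatter of each other. Compound 3 (`C[C@H](NC(=O)c1ccc(C#N)cc1)c1ccc(NC(=O)[C@H]2C[C@@H]2c2cccnc2)cc1`) has cyano in place of fluoro on an aromatic carbon para to a large group. Among the measured compounds shown here, the one measured step (a 1.8-fold lower number from compound 1 to compound 2 (0.26 log units; within the scatter)) replaced a different group and stayed within the scatter, so it gives no direction for this change. In this assay the expected change is a 1.1-fold lower number from compound 2 to compound 3 (0.02 log units; within the scatter) and thus none beyond the scatter. For compound 3 the estimated value is 13 mL.min-1.g-1 (range 6.5 mL.min-1.g-1 to 26 mL.min-1.g-1).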

Compound 3, intrinsic clearance in microsomes: 53 mL.min-1.g-1
Compound 3: the middle estimate sits 4.1-fold (0.61 log units) below what was measured, outside the stated range (above it).
By their numbers in this assay, from the lowest: compounds 2 and 1 (each within the scatter of the next); then compound 3.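

In this assay cyano in place of fluoro on this aromatic carbon gives a 3.9-fold higher number from compound 2 to compound 3 (0.59 log units; beyond the scatter) and so shows that a swap at this one position can move the read-out beyond the scatter, which the earlier pair could not show. The aromatic group is also not interchangeable with oxan-4-yl in every form, since 4-cyanophenyl gives a 2.1-fold higher number from compound 1 to compound 3 (0.32 log units; beyond the scatter) while 4-fluorophenyl stayed within the scatter. Nothing available here bears on why the number rises.

From the compounds shown here alone, whether other groups on this carbon, such as methoxy or an amine, would raise the number as well remains open.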